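A few compounds are considered here, and "the series" means these few. Any claim that something is new, unique, unknown or untested is made for them only; others in the source may bear on it.

Series notes. Compound 1 `CC(C)CCn1c(Cn2c(=O)n(C(C)C)c3ccccc32)nc2cc(CNS(C)(=O)=O)ccc21` and compound 2 `CC(C)CCn1c(Cn2c(=O)n(C(C)C)c3ccccc32)nc2cccc(CN)c21` share a core and have both been measured in an ADME assay on HEp-2 cells (Homo sapiens) for cytotoxicity; a lower number here means that less compound is tolerated, a higher number that more compound is tolerated. In this assay compound 1 gives 30800 nM, the highest of the two numbers. Compound 2 gives 11000 nM, a gap beyond the usual scatter. Compound 3 `CC(C)CCn1c(Cn2c(=O)n(C(C)C)c3ccccc32)nc2cc(C(N)=O)ccc21` is not yet measured. It differs from compound 1 in one place: carbamoyl in place of (methanesulfonamido)methyl on an aromatic carbon. Among the measured compounds shown here, no measured pair shows this change. The expected step is a 1.4-fold lower number from compound 1 to compound 3 (0.15 log units; within the scatter), small, toward a lower number and possibly not beyond the scatter. For compound 3 the estimate in this assay is 22000 nM, with a range from 8000 nM to 55000 nM.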

Compound 3, half-maximal cytotoxic concentration: 23400 nM
Compound 3: the middle estimate sits 1.1-fold (0.03 log units) below what was measured; the range from low to high includes it.
By their numbers in this assay, from the lowest: compound 2; then compounds 3 and 1 (each within the scatter of the next).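

In this assay, among the compounds shown here, carbamoyl in place of (methanesulfonamido)methyl on this aromatic carbon gives a 1.3-fold lower number from compound 1 to compound 3 (0.12 log units; within the scatter), the first single-place comparison. At this position, the two groups cannot be told apart in this read-out, although they differ in size and in the sulfur they carry. Nothing available explains this result.

Going by these compounds, whether a carboxylic acid, an amine or a longer chain on the same carbon would also stay within the scatter of compound 1 remains open. On these data alone, whether this exchange behaves the same way on another aromatic carbon of the shared core is also open.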